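The source may hold more compounds than are shown below. What is called first, only, known or untested is meant among the compounds shown, and "the series" means these compounds.

For the measured compounds named here, compound 2 `O=C(O)Cc1sc(Cc2ccc(Cl)cc2)nc1-c1ccc(Cl)cc1` gives 50 nM in an in vitro assay on COS-7 cells for displacement of a labelled ligand from prostaglandin D2 receptor 2 (Homo sapiens) (a higher number here means a weaker inhibitor, a lower number a stronger inhibitor), the lower of the two numbers measured; compound 1 `COc1ccc(-c2nc(-c3ccc(OC)cc3)c(CC(=O)O)s2)cc1` gives 4100 nM in this assay, and the two differ in more than one place, so they show only that compound 2 is the stronger of the pair. Compound 3 `COc1ccc(-c2nc(Cc3ccc(Cl)cc3)sc2CC(=O)O)cc1` arises from compound 2 by methoxy in place of chloro on an aromatic carbon. Going by the values given here, no single-change step between measured compounds is known here. Compound 3 is expected to be a somewhat weaker inhibitor, with a step of a 3.0-fold higher number from compound 2 to compound 3 (0.48 log units; beyond the scatter) that lies somewhat beyond the scatter. Compound 3 is estimated at 150 nM, in a range from 50 nM to 500 nM.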

Compound 3, half-maximal inhibitory concentration: 360 nM
Estimate against measurement, compound 3: 2.4-fold (0.38 log units) below; measured number inside the range.
By their numbers in this assay, from the lowest: compound 2; then compound 3; then compound 1.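

In this assay, this para site on the aromatic ring responds clearly to the swap: 4-chlorophenyl to 4-methoxyphenyl gives a 7.2-fold higher number from compound 2 to compound 3 (0.86 log units; beyond the scatter) with the 4-chlorobenzyl group held fixed. Where 4-methoxyphenyl stays at this site, 4-chlorobenzyl in place of the other 4-methoxyphenyl gives an 11-fold lower number from compound 1 to compound 3 (1.06 log units; beyond the scatter). Nothing here explains either step. Open, going by these compounds, is how a fluoro, methyl, hydroxy or amino group would read at this site, and whether any matches chloro.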